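Methyl on an aromatic nitrogen: paw edema series notes

A few compounds are considered here, and "the series" means these few. Any claim that something is new, unique, unknown or untested is made for them only; others in the source may bear on it.

Compound 1 `COc1ccc(Cl)c(-c2nnc3n2NC(c2ccc[nH]2)S3)c1`, compound 2 `COc1ccc(Cc2nnc3n2NC(c2ccc[nH]2)S3)cc1OC` and compound 3 `COc1ccc(Cl)c(-c2nnc3n2NC(c2cccn2C)S3)c1` have been run in a functional assay on the whole organism (strain Wistar Albino) for inhibition, with Rattus norvegicus as the target, read by paw edema, with a stated time of 4 h, at a dose of 20 mg/kg; on this read-out higher numbers stand for more inhibition at the one dose given (going by the name of the read-out) and lower numbers for less inhibition. Compound 1 gives 20.6%, compound 2 gives 21.5% and compound 3 gives 20.7% in this assay, all three within the usual scatter of one another. The difference between the cores of compound 1 and compound 2 is not broken down here. Compound 3 differs from compound 1 by methyl in place of hydrogen on an aromatic nitrogen and this gave a number 0.1 percentage points higher from compound 1 to compound 3 (within the scatter). Compound 4 `COc1ccc(Cc2nnc3n2NC(c2cccn2C)S3)cc1OC`, still to be measured, carries the same change on compound 2, namely (methyl in place of hydrogen on an aromatic nitrogen). For the measured compounds named here, with only one measured instance of this change, the step is expected to be a number 0.5 percentage points higher from compound 2 to compound 4 (within the scatter) in this assay. Compound 4 is estimated at 22% because compound 2 gives 21.5% and the change gave a number 0.1 percentage points higher from compound 1 to compound 3 (within the scatter), with a range from 14% to 30%.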

Compound 4, a percentage reported as inhibition, in the whole organism at one dose (the size of the read-out at that dose, not a potency): 19.9%
The estimate for compound 4 lay 2.1 percentage points above the measured number, and the stated range covers the measured number.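

In this assay, methyl in place of hydrogen on an aromatic nitrogen gives a number 1.6 percentage points lower from compound 2 to compound 4 (within the scatter). The change 1H-pyrrol-2-yl to 1-methyl-1H-pyrrol-2-yl carries across the two cores with no difference that can be read: the same change on two cores in this assay, a number 0.1 percentage points higher (within the scatter) from compound 1 to compound 3 and a number 1.6 percentage points lower (within the scatter) from compound 2 to compound 4, 1.7 percentage points apart, within the scatter of two such steps On these two cores, at this one dose and time, the change leaves the read-out within the scatter, but this does not show a small real effect in either direction or say anything about potency.

The compounds shown leave open whether a longer chain such as butyl on that aromatic nitrogen would move the read-out beyond the scatter. They also leave open whether a chain ending in an amine or a carboxylic acid would do so.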